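This account rests on a few compounds, and the source may have more. Where it says the series, first, only, none or still open, it means among the compounds named here.

Compound 1 `CN(C)c1ccc(C2CC(c3ccc(-n4ccnc4)cc3)=NN2C(=O)c2ccc(F)cc2)cc1` gives 7.1% in a functional assay on HCC1806 cells (Homo sapiens) for inhibition, read by sulforhodamine B assay, tested at 10 uM; a higher number here means more inhibition at the concentration tested (going by the name of the read-out), a lower number less inhibition. Compound 2 `Cc1ccc(S(=O)(=O)N2N=C(c3ccc(-n4ccnc4)cc3)CC2c2ccc(N(C)C)cc2)cc1` gives 66% in this assay.

Among the measured compounds shown here, of these two, compound 2 stands higher: the single measured step, a number 58.9 percentage points higher from compound 1 to compound 2 (beyond the scatter), separates it from compound 1, which is its only neighbour. Compound 3 `CN(C)c1ccc(C2CC(c3ccc(-n4ccnc4)cc3)=NN2S(=O)(=O)c2ccc(C#N)cc2)cc1` is the next compound, and it differs from compound 2 by cyano in place of methyl on an aromatic carbon.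

For the measured compounds named here, no measured step touches this change. Going by the values given here, the one step known, a number 58.9 percentage points higher from compound 1 to compound 2 (beyond the scatter), concerns the group on the ring nitrogen, not the substituent on the outer aromatic ring, so it says nothing about what swapping methyl for cyano does. With no guide, the expected step is one that stays within the usual scatter, a number 4 percentage points lower from compound 2 to compound 3 (within the scatter), and the uncertainty around it is wide. Compound 3 is therefore estimated at 62%, with a range from 30% to 85%.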

Compound 3, a percentage reported as inhibition, at one concentration (the size of the read-out at that concentration, not a potency): 4.7%
For compound 3 the middle estimate is 57.3 percentage points above the measured one; measured number outside the range, below it.
By their numbers in this assay, from the lowest: compounds 3 and 1 (each within the scatter of the next); then compound 2.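

The substituent on this aromatic carbon, para to a large group, strongly shapes the result in this assay: replacing methyl with cyano gives a large fall (a number 61.3 percentage points lower from compound 2 to compound 3 (beyond the scatter)). The (4-methylphenyl)sulfonyl group of compound 2 therefore cannot be treated as just any arylsulfonyl group, since a sulfonyl group alone does not guarantee a high number. Replacing (4-fluorophenyl)carbonyl with (4-cyanophenyl)sulfonyl on the ring nitrogen leaves the two compounds within the usual scatter (a number 2.4 percentage points lower from compound 1 to compound 3 (within the scatter)). No available evidence explains the fall seen with cyano.

On these data alone, it remains open whether a methoxy group, a chlorine atom or an ethyl group on the same carbon would keep the number near that of compound 2. A (4-methylphenyl)carbonyl group on the ring nitrogen would test whether methyl helps without the sulfonyl.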